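This account rests on a few compounds, and the source may have more. Where it says the series, first, only, none or still open, it means among the compounds named here.

Measured in a functional assay on HeLa cells (Homo sapiens) for inhibition, read by MTT assay, with a stated time of 48 h; on this read-out higher numbers stand for weaker inhibition and lower numbers for stronger inhibition:
- Compound 1 `COc1cccc(NC(=O)/C=C/c2coc3cc(OC)ccc3c2=O)c1`: 19200 nM
- Compound 2 `COc1ccc2c(=O)c(/C=C/C(=O)NCc3cccc(F)c3)coc2c1`: 17600 nM
- Compound 3 `COc1ccc2c(=O)c(/C=C/C(=O)Nc3ccc(Cl)cc3)coc2c1`: > 100000 nM, a limit of the assay

Compound 3 stands at the limit of > 100000 nM in this assay, at which 1 of the 3 values shown sits, so it is known only as a limit. Compound 4 `COc1ccc2c(=O)c(/C=C/C(=O)NCc3ccc(F)cc3F)coc2c1` carries 2,4-difluorobenzyl in place of 4-chlorophenyl on an amide-type nitrogen.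

Among the compounds with values here, three measured steps bear on this change. The nearest is an at least 5.6-fold higher number from compound 2 to compound 3 (0.75 log units; beyond the scatter), which swaps 3-fluorobenzyl for 4-chlorophenyl, the reverse kind of change. Similar is an at least 5.2-fold higher number from compound 1 to compound 3 (0.71 log units; beyond the scatter), while a 1.1-fold lower number from compound 1 to compound 2 (0.04 log units; within the scatter) shows no separation between the other two amides. A lower number is therefore expected in this assay, of roughly the size of those steps to compound 3. The expected step is an at least 5.0-fold lower number from compound 3 to compound 4 (0.69 log units; beyond the scatter). Compound 4 is estimated at 20000 nM, with an expected range of 7000 nM to 60000 nM.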

Compound 4, half-maximal inhibitory concentration: > 100000 nM
Compound 4 ended at the assay's limit (the forecaster's own chance of this, stated with the estimate: 15%); middle value at least 5.0-fold (0.69 log units) away from the limit.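

In this assay a benzyl group on the amide-type nitrogen did not by itself hold the number down: going from 3-fluorobenzyl to 2,4-difluorobenzyl gave an at least 5.6-fold higher number from compound 2 to compound 4 (0.75 log units; beyond the scatter) with only the fluorine pattern altered. Replacing 3-methoxyphenyl with 2,4-difluorobenzyl gave an at least 5.2-fold higher number from compound 1 to compound 4 (0.71 log units; beyond the scatter) in the same direction. Compound 3 and compound 4 both sit at a limit, so the step between them cannot be read: the limit of > 100000 nM in this assay, at which 2 of the 4 values shown sit.

Going by these compounds, how far compound 3 and compound 4 lie past that limit stays open. Also open, on these data alone, is whether an unsubstituted benzyl, or a longer chain such as phenethyl, on the amide-type nitrogen would read like compound 2 or like compound 4.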